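Working notes: (4-chlorophenyl)carbamoyl step from compound 3

The compounds below may be only part of what the source reports. "The series", "measured", "known", "first", "only" and "open" are said of these compounds alone.

Of the compounds shown here, three have numbers so far in a functional assay on MDA-MB-436 cells (Homo sapiens) for antiproliferative activity, read by MTT assay, with a stated time of 48 h; a higher number here means a weaker inhibitor, a lower number a stronger inhibitor. Compound 1 `C=CS(=O)(=O)N1CCN(c2ncnc3sc(-c4ccnc(Cl)c4)cc23)CC1` gives 30100 nM, and compound 2 `C=CS(=O)(=O)N1CCN(c2ncnc3sc(-c4cnn(Cc5ccccc5)c4)cc23)CC1` gives 18300 nM. Compound 3 `CCS(=O)(=O)N1CCN(c2ncnc3sc(-c4ccc(N5CCN(C)CC5)cc4)cc23)CC1` gives 10600 nM. That number lies below the value of compound 1 by more than the scatter, but it cannot be separated from the value of compound 2.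

Compound 4 `CN1CCN(c2ccc(-c3cc4c(N5CCN(C(=O)Nc6ccc(Cl)cc6)CC5)ncnc4s3)cc2)CC1` is still unmeasured in this assay. Its difference from compound 3 is (4-chlorophenyl)carbamoyl in place of ethylsulfonyl on an amine nitrogen in a ring. Among the measured compounds shown here, no two measured compounds differ in one place, so the data give no direct measure of a step of this kind. For the measured compounds named here, the only guide is the spread of the series, which runs from compound 3 at 10600 nM to compound 1 at 30100 nM. A modest move towards a lower number is expected, only slightly beyond the scatter, and the uncertainty on its size and direction is wide. The expected change is a 2.1-fold lower number from compound 3 to compound 4 (0.33 log units; beyond the scatter). For compound 4 the estimated value is 5000 nM, with an expected range of 1200 nM to 22000 nM.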

Compound 4, half-maximal inhibitory concentration: 9270 nM
Compound 4: middle estimate off by 1.9-fold (0.27 log units), on the low side; measured number inside the range.
By their numbers in this assay, from the lowest: compounds 4, 3, 2 and 1 (each within the scatter of the next, the first and the last beyond it).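

Among the compounds shown here, this is the first step that changes a single place. On an amine nitrogen in a ring, (4-chlorophenyl)carbamoyl in place of ethylsulfonyl gives a 1.1-fold lower number from compound 3 to compound 4 (0.06 log units; within the scatter) in this assay. The antiproliferative read-out therefore does not separate the two compounds, even though the entering group is larger and brings a six-membered aromatic ring of carbon only and a hydrogen-bond donor that ethylsulfonyl lacks. No measurement shown accounts for this result, so it remains an observation about this single pair.

One step on one background cannot show whether this nitrogen accepts substituents in general, since the other substituent on the shared core stays the same in compound 3 and compound 4. As far as these compounds go, it also remains open whether a plain acetyl on the same nitrogen, or an amine or a carboxylic acid in place of the chlorine on the aromatic ring of the carbamoyl group, would move the number beyond the scatter.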